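Bromo for Methyl on a Nitroimidazole Side Arm

The source may report more compounds than this note shows. Statements on the series, on what has been measured and on what is new or still open speak of the compounds shown alone.

Compound 1 `Cc1ccc(C(Br)C(Br)c2ncc([N+](=O)[O-])n2C)cc1` was tested in an ADME assay on HeLa cells (Homo sapiens) for cytotoxicity, read by resazurin assay, with a stated time of 2 days (on this read-out higher numbers stand for weaker inhibition and lower numbers for stronger inhibition), where compound 1 gives 11200 nM. Compound 2 `Cc1cccc(/C=C/c2ncc([N+](=O)[O-])n2C)c1` and compound 3 `Cn1c([N+](=O)[O-])cnc1/C=C/c1cccc(Br)c1` share a core that is not the core of compound 1, and the difference between the two cores is not broken down here. In this assay compound 2 gives 30900 nM and compound 3 gives 87100 nM. The change between these two, (bromo in place of methyl on an aromatic carbon), made a 2.8-fold higher number from compound 2 to compound 3 (0.45 log units; beyond the scatter). Compound 4 `Cn1c([N+](=O)[O-])cnc1C(Br)C(Br)c1ccc(Br)cc1` has not yet been measured. It arises from compound 1 by the same kind of change, (bromo in place of methyl on an aromatic carbon), though here the bromo sits para to a large group rather than meta to a large group. Because the earlier step of a 2.8-fold higher number from compound 2 to compound 3 (0.45 log units; beyond the scatter) was modest and beyond the scatter, for compound 4 a step of a 2.5-fold higher number from compound 1 to compound 4 (0.40 log units; beyond the scatter) is expected in this assay, resting only on that single comparison. The value expected for compound 4 in this assay is therefore 28000 nM, with a likely range from 10000 nM to 80000 nM.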

Compound 4, half-maximal inhibitory concentration: 7940 nM
Compound 4: the middle estimate sits 3.5-fold (0.55 log units) above what was measured, outside the stated range (below it).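

On the core of compound 1, putting bromo in place of methyl gives a 1.4-fold lower number from compound 1 to compound 4 (0.15 log units; within the scatter) in this assay, so this swap produces no change that can be told apart from ordinary repeat variation on this core. The swap therefore does not carry over at the same size from one core to the other: the same change on two cores in this assay, a 2.8-fold higher number (0.45 log units; beyond the scatter) from compound 2 to compound 3 and a 1.4-fold lower number (0.15 log units; within the scatter) from compound 1 to compound 4, 4.0-fold (0.60 log units) apart, beyond the scatter of two such steps This does not show what sets the two steps apart or how the swap would behave on any further core, since each core offers a single pair and the bromo sits para to a large group in compound 4 but not in compound 3.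

The compounds shown leave open whether the two steps would agree with the bromo in the same place on both cores. They also leave open whether a chloro group, a methoxy group or an amine in place of the methyl would give steps that differ between the two cores.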